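A Halogen Swap on the Styryl Arm

The compounds below may be only part of what the source reports. "The series", "measured", "known", "first", "only" and "open" are said of these compounds alone.

Measured so far:
compound 1, `COC(=O)/C=C/c1cccc(N(Cc2ccc(/C=C/C(=O)O)cc2)C(=O)C2CCCCC2)c1`: 1000 nM
compound 2, `COC(=O)/C=C/c1cccc(N(Cc2ccc(/C=C/c3c(Cl)cccc3Cl)cc2)C(=O)C2CCCCC2)c1`: 151 nM
compound 3, `COC(=O)/C=C/c1cccc(N(Cc2ccc(/C=C/c3cccc(Cl)c3)cc2)C(=O)C2CCCCC2)c1`: 166 nM

In an assay on isolated protein with Bile acid receptor (Homo sapiens) as the target (on this read-out lower numbers stand for an effect already at smaller amounts and higher numbers for an effect only at larger amounts of compound), compound 3 stands second highest of the three numbers. Its nearest neighbour is compound 2, as a 1.1-fold higher number from compound 2 to compound 3 (0.04 log units; within the scatter) shows, a gap within the scatter; its furthest is compound 1, a 6.0-fold lower number from compound 1 to compound 3 (0.78 log units; beyond the scatter). Compound 4 `COC(=O)/C=C/c1cccc(N(Cc2ccc(/C=C/c3ccc(F)cc3)cc2)C(=O)C2CCCCC2)c1` differs from compound 3 by 4-fluorophenyl in place of 3-chlorophenyl on a double-bonded chain carbon bound to a double-bonded chain carbon. Going by the values given here, no measured step changes one aryl halogen for another; the two steps that reach compound 2 and compound 3, a 6.6-fold lower number from compound 1 to compound 2 (0.82 log units; beyond the scatter) and a 6.0-fold lower number from compound 1 to compound 3 (0.78 log units; beyond the scatter), replace the carboxy group and are alike in size, and a 1.1-fold higher number from compound 2 to compound 3 (0.04 log units; within the scatter) shows the chlorination pattern barely matters. Compound 4 is therefore expected to stay near compound 3, with a 1.5-fold higher number from compound 3 to compound 4 (0.18 log units; within the scatter), at an estimated 250 nM in this assay, within 100 nM to 600 nM.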

Compound 4, half-maximal effective concentration: 186 nM
For compound 4 the middle estimate is 1.3-fold (0.13 log units) above the measured one; the measured number falls inside the stated range.
By their numbers in this assay, from the lowest: compounds 2, 3 and 4 (each within the scatter of the next); then compound 1.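

In this assay the 4-fluorophenyl group, the first fluorine at this place, cannot be told apart from either chlorinated phenyl (a 1.1-fold higher number from compound 3 to compound 4 (0.05 log units; within the scatter); a 1.2-fold higher number from compound 2 to compound 4 (0.09 log units; within the scatter)). It also keeps the distance from the carboxy compound (a 5.4-fold lower number from compound 1 to compound 4 (0.73 log units; beyond the scatter)), so among compounds 2, 3 and 4 neither the choice of halogen nor the substitution pattern on the phenyl moves the number beyond the scatter. Nothing in the data given here accounts for this tolerance. Still open, on these data alone, is how an unsubstituted phenyl, or a phenyl bearing an amine or a methoxy group, would read at this place.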